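This account rests on a few compounds, and the source may have more. Where it says the series, first, only, none or still open, it means among the compounds named here.

Compound 1 `COc1ncnc2c1c(-c1cccs1)cn2[C@@H]1O[C@H](CO)[C@@H](O)[C@H]1O` carries a methoxy group on the shared core. In a functional assay on K562 cells (Homo sapiens), read by MTT assay, with a stated time of 72 h (a higher number here means a weaker inhibitor, a lower number a stronger inhibitor), compound 1 gives 70 nM, the only number shown. Compound 2 `COc1ncnc2c1c(-c1ccccc1)cn2[C@@H]1O[C@H](CO)[C@@H](O)[C@H]1O` gives only a limit of > 20000 nM in this assay, at which 1 of the 2 values shown sits, in this assay, reported as > 20000 nM. The step of an at least 280-fold higher number from compound 1 to compound 2 (2.45 log units; beyond the scatter) concerns a different place on the core. Compound 3 `CN(C)c1ncnc2c1c(-c1cccs1)cn2[C@@H]1O[C@H](CO)[C@@H](O)[C@H]1O` differs from compound 1 by dimethylamino in place of methoxy on an aromatic carbon. For the measured compounds named here, no measured step touches this position, so the direction of the step is unknown and a modest weakening is expected. Compound 3 is therefore expected to give 500 nM in this assay, between 100 nM and 5000 nM, a step of a 7.1-fold higher number from compound 1 to compound 3 (0.85 log units; beyond the scatter).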

Compound 3, half-maximal inhibitory concentration: > 20000 nM
Compound 3 was reported as a limit; the forecaster's own chance of this, stated with the estimate: 10%; at least 40-fold (1.60 log units) between middle value and limit.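

Dimethylamino in place of methoxy, at a position no earlier step had touched, gives an at least 280-fold higher number from compound 1 to compound 3 (2.45 log units; beyond the scatter) in this assay. So, with the thiophen-2-yl group kept, a change at this position alone takes compound 1 from a measurable value to a limit, just as the phenyl change did at the other place. Compound 3 gives a limit of the assay and not a number, which it shares with compound 2: the limit of > 20000 nM in this assay, at which 2 of the 3 values shown sit.

As far as these compounds go, whether a primary amine, methylamino or ethoxy at this position would keep a value close to that of compound 1 stays open. From the compounds shown here alone, the step's true size also stays open, since one end of it is a limit.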